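Two Limit Values and a Chlorophenyl Variant

A few compounds are considered here, and "the series" means these few. Any claim that something is new, unique, unknown or untested is made for them only; others in the source may bear on it.

compound 1 `O=C(O)c1csc([C@H]2CC[C@@H]3[C@@H](/C=C/COc4ccccc4)[C@H](O)C[C@@H]3O2)n1`: > 10000 nM
compound 2 `Cc1ccc(OC[C@@H]2[C@H]3CC[C@H](c4nc(C(=O)O)cs4)O[C@H]3C[C@H]2O)cc1`: > 10000 nM

In an assay on HEK293 cells for agonist activity at prostaglandin E2 receptor EP2 subtype (Homo sapiens), read by a beta-galactosidase reporter and beta-arrestin recruitment, with a stated time of 90 min (a higher number here means that more compound is needed for the effect, a lower number that less compound is needed), compound 1 gives only a limit, > 10000 nM. In this assay compound 2 likewise gives only a limit, > 10000 nM. Compound 2 therefore stands at the limit rather than at a number, and both values shown sit there (the limit of > 10000 nM in this assay, at which 2 of the 2 values shown sit). Compound 3 `O=C(O)c1csc([C@H]2CC[C@@H]3[C@@H](COc4ccccc4Cl)[C@H](O)C[C@@H]3O2)n1` differs from compound 2 by 2-chlorophenyl in place of 4-methylphenyl on an oxygen on a saturated carbon. Among the measured compounds shown here, no measured step covers this change, so no step beyond the scatter is expected in this assay, and a limit is again the most likely outcome. The step is expected to be a step that the limit leaves unreadable from compound 2 to compound 3. Compound 3 is thus estimated at 15000 nM, between 4000 nM and 50000 nM.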

Compound 3, half-maximal effective concentration: 203 nM
Compound 3: the middle estimate sits 74-fold (1.87 log units) above what was measured, and the stated range ends above it.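

In this assay, this position on an oxygen on a saturated carbon gives the first readable value: 2-chlorophenyl in place of 4-methylphenyl brings an at least 49-fold lower number from compound 2 to compound 3 (1.69 log units; beyond the scatter). The earlier compounds shown here, both only at a limit, showed no sensitivity to any change. The size of this step remains a bound and not an exact figure, because compound 2 has only a limit: the limit of > 10000 nM in this assay, at which 2 of the 3 values shown sit.

From the compounds shown here alone, whether the chlorine itself or its place on the ring carries the step stays open. So does how 2-methylphenyl or 4-chlorophenyl would read at this position.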